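The source may hold more compounds than are shown below. What is called first, only, known or untested is meant among the compounds shown, and "the series" means these compounds.

Among the compounds with values here, in a functional assay on SK-N-SH cells (Homo sapiens) for inhibition, read by MTT assay, with a stated time of 72 h, tested at 30 uM (on this read-out lower numbers stand for less inhibition of growth and higher numbers for more inhibition of growth at the one concentration tested), compound 1 (`C=CCc1cc(O)c(O)c(CN2CCC(C)CC2)c1`) reaches 74.7% and stands highest of the two compounds measured so far. The other one, compound 2 (`C=CCc1ccc(OCc2cn(-c3ccccc3Cl)nn2)c(O)c1`), gives 10.2% and so lies lower by a gap well beyond the usual scatter of repeated measurements. Compound 3 (`C=CCc1cc(O)c(O)c(CN2CCC(CO)CC2)c1`) has not been measured yet. It keeps the core of compound 1 and changes it in one place (hydroxy in place of hydrogen on a saturated chain carbon bound to a saturated ring carbon). Here hydroxy stands in place of hydrogen on a saturated chain carbon bound to a saturated ring carbon, which turns methyl to hydroxymethyl. Within the data shown here, no measured pair of compounds shows what this kind of change does, so the forecast carries real uncertainty. The closest measured relative is compound 1 at 74.7% and the forecast therefore stays near that number. In this assay the expected step of a number 8.7 percentage points lower from compound 1 to compound 3 (within the scatter) is a small fall in growth inhibition, and its estimated size does not go beyond the usual scatter. For compound 3 the estimated value is 66%, with an expected range (45% to 82%).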

Compound 3, percent growth inhibition at one concentration: 21.9%
For compound 3 the middle estimate is 44.1 percentage points above the measured one; measured number outside the range, below it.
By their numbers in this assay, from the lowest: compound 2; then compound 3; then compound 1.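

In this assay, placing hydroxy in place of hydrogen on a saturated chain carbon bound to a saturated ring carbon, which turns methyl to hydroxymethyl, gives a number 52.8 percentage points lower from compound 1 to compound 3 (beyond the scatter) in this pair. This is the first pair shown that differs in only one place, and it shows that this position is far from indifferent: one added oxygen atom, with the rest of the core of compound 1 unchanged, removes most of the growth inhibition seen at the one concentration tested. No measurement here explains why this small change has so large an effect.

The pair cannot separate an effect of the hydroxy itself from an effect of any change at this carbon, and a methoxymethyl, an aminomethyl, a carboxylic acid or a longer chain such as ethyl at the same place would help to tell these apart. It also leaves open whether the same change from methyl to hydroxymethyl would lower growth inhibition as strongly on a different core.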